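The source may report more compounds than this note shows. Statements on the series, on what has been measured and on what is new or still open speak of the compounds shown alone.

Measured in a functional assay on A549 cells (Homo sapiens) for antiproliferative activity, read by MTT assay, with a stated time of 72 h; on this read-out lower numbers stand for stronger inhibition and higher numbers for weaker inhibition:

- compound 1 `Cc1ccc(SC(=S)N2CCN(C(=O)OC(C)(C)C)CC2)cc1`: 2110 nM
- compound 2 `COc1ccc(SC(=S)N2CCN(C(=O)OC(C)(C)C)CC2)cc1`: 712 nM
- compound 3 `CC(C)(C)OC(=O)N1CCN(C(=S)Sc2ccc(Br)cc2)CC1`: 1820 nM

Among these three compounds, compound 3 sits with compound 1 rather than with compound 2. The a 1.2-fold lower number from compound 1 to compound 3 (0.06 log units; within the scatter) lies within the scatter, whereas a 2.6-fold higher number from compound 2 to compound 3 (0.41 log units; beyond the scatter) lies beyond it.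

The unmeasured compound 4 `Cc1cccc(SC(=S)N2CCN(C(=O)OC(C)(C)C)CC2)c1` differs from compound 3 by a single change, 3-methylphenyl in place of 4-bromophenyl on a sulfur. Compound 1 also carries a methyl group on its aromatic ring, which makes it the closest measured relative of compound 4. Swapping methyl for bromo on the ring barely registered in a 1.2-fold lower number from compound 1 to compound 3 (0.06 log units; within the scatter). This suggests that compound 4 should land near compound 1 at 2110 nM. However, no measured pair shows what moving the methyl group alone does. The a 3.0-fold lower number from compound 1 to compound 2 (0.47 log units; beyond the scatter) also shows that a different group on this ring can shift the number modestly, so the range must stay wide.

In this assay, the expected outcome is a 1.1-fold higher number from compound 3 to compound 4 (0.04 log units; within the scatter), which means no change beyond the scatter is expected. For compound 4 the estimate is 2000 nM, with an expected range from 900 nM to 4500 nM.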

Compound 4, half-maximal inhibitory concentration: 914 nM
Compound 4: middle estimate off by 2.2-fold (0.34 log units), on the high side, and the stated range covers the measured number.
By their numbers in this assay, from the lowest: compounds 2, 4, 3 and 1 (each within the scatter of the next, the first and the last beyond it).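

The new information comes from moving the methyl group alone: in this assay there is a 2.3-fold lower number from compound 1 to compound 4 (0.36 log units; beyond the scatter) when 3-methylphenyl replaces 4-methylphenyl on the sulfur. For the compounds shown here, both groups have the same name apart from the place of the methyl, yet the step lies beyond the scatter, so where the methyl sits on this ring can modestly change the number, which the earlier compounds could not show. The other two steps, a 2.0-fold lower number from compound 3 to compound 4 (0.30 log units; within the scatter) and a 1.3-fold higher number from compound 2 to compound 4 (0.11 log units; within the scatter), both lie within the scatter, so this assay does not separate compound 4 from compound 3 or from compound 2. Nothing among the data shown explains why the place of the methyl matters.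

Methyl is the only group seen in two places on the ring, so it remains open whether bromo or methoxy would respond in the same way to such a move. As far as these compounds go, it is also open how the number would respond to a quite different group on this ring, such as an amine, a carboxylic acid or a longer chain.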